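Shortening the chain of a compound at the assay limit

The source may hold more compounds than are shown below. What is called first, only, known or untested is meant among the compounds shown, and "the series" means these compounds.

Compound 3 (`CCCCCCCCCCCCCCCCOP(=O)(O)OCCSC(=S)N1CCN(C)CC1`) gives > 100000 nM in a functional assay on MDA-MB-231 cells (Homo sapiens) for inhibition, read by MTT assay, with stated times of 18 h and 4 h (a higher number here means a weaker inhibitor, a lower number a stronger inhibitor), and this is a limit of the assay, not a number. Compound 4 (`CCCCCCCCCCOP(=O)(O)OCCSC(=S)N1CCN(C)CC1`) differs from it only in the chain: hydrogen in place of hexyl on a saturated chain carbon, ten or more bonds along the chain from an oxygen on an unsaturated carbon. Among the compounds with values here, no measured pair changes this chain, so no step speaks to it directly. The nearest guide comes from two compounds that already carry the shorter chain of compound 4, though with other groups on the thiocarbonyl carbon. In this assay compound 1 (`CCCCCCCCCCOP(=O)(O)OCCSC(=S)N1CCCCCC1`) gives 11400 nM, and compound 2 (`CCCCCCCCCCOP(=O)(O)OCCSC(=S)N1CCCC1`) gives 67000 nM. Within the data shown here, only that group changes between them, and the result is a 5.9-fold higher number from compound 1 to compound 2 (0.77 log units; beyond the scatter), so the group alone can move the number noticeably. Compound 4 keeps the group of compound 3, which neither of these two carries, so the guide is a loose one. A move to a lower number, meaning a stronger inhibitor, is expected, with an estimated size of an at least 2.8-fold lower number from compound 3 to compound 4 (0.45 log units; beyond the scatter). For compound 4 the estimated value is 35000 nM, with an expected range of 10000 nM to 100000 nM.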

Compound 4, half-maximal inhibitory concentration: 29000 nM
For compound 4 the middle estimate is 1.2-fold (0.08 log units) above the measured one, within the range that was stated.
By their numbers in this assay, from the lowest: compound 1; then compound 4; then compound 2. At a limit, above all of these: compound 3.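

In this assay, taking the hexyl off this chain gives an at least 3.4-fold lower number from compound 3 to compound 4 (0.53 log units; beyond the scatter), the first measured sign that the length of the chain matters. Compound 3 stands at a limit and not at a number, so this step sets only a floor for the change: the limit of > 100000 nM in this assay, at which 1 of the 4 values shown sits. With the shorter chain, the 4-methylpiperazin-1-yl group takes a middle place among the groups on the thiocarbonyl carbon, with a 2.3-fold lower number from compound 2 to compound 4 (0.36 log units; beyond the scatter) and a 2.5-fold higher number from compound 1 to compound 4 (0.41 log units; beyond the scatter).

Open, going by these compounds, is how a chain of intermediate length, such as dodecyl, or a still shorter one, such as octyl, would fall, and whether the azepan-1-yl and pyrrolidin-1-yl groups respond to chain length in the same way. Also open, on these data alone, is how an open-chain amine such as diethylamino would compare on the thiocarbonyl carbon.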